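The source may hold more compounds than are shown below. What is called first, only, known or untested is meant among the compounds shown, and "the series" means these compounds.

Measured so far in an assay on isolated protein for inhibition of MAP kinase-interacting serine/threonine-protein kinase 1 (Homo sapiens), tested at 10 uM; a lower number here means less inhibition, a higher number more inhibition at the concentration tested (going by the name of the read-out):
- compound 1 `COc1cc(O)c(C(=O)OCC2CCCCC2)c(/C=C/CN2C(=O)C=CC2=O)c1`: 9.7%
- compound 2 `COc1cc(O)c(C(=O)OC(C)C)c(/C=C/CN2C(=O)C=CC2=O)c1`: 5.4%
- compound 3 `CCN(CC)C/C=C/C(=O)NC/C=C/c1cc(OC)cc(O)c1C(=O)OC(C)C`: 12.5%

All three numbers lie close together; compound 3 is separated from compound 1 and from compound 2 by gaps that stay within the usual scatter of this assay. Among the measured compounds shown here, the one single-point step measured, a number 4.3 percentage points lower from compound 1 to compound 2 (within the scatter), concerns the ester alcohol and is itself within the scatter.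

Compound 4 `CCN(CC)C/C=C/C(=O)NC/C=C/c1cc(OCCc2ccc(F)cc2)cc(O)c1C(=O)OC(C)C` differs from compound 3 by 4-fluorobenzyl in place of hydrogen on a saturated chain carbon bound to an oxygen on an aromatic ring. For the measured compounds named here, no measured step touches this position, so the only guidance is that the series has so far moved within the scatter; the step of a number 0.5 percentage points lower from compound 3 to compound 4 (within the scatter) is therefore expected to be small, with no direction claimed. Compound 4 is estimated at 12% (range 0% to 30%) in this assay.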

Compound 4, a percentage reported as inhibition, at one concentration (the size of the read-out at that concentration, not a potency): 7.8%
Compound 4: middle estimate off by 4.2 percentage points, on the high side; the range from low to high includes it.
By their numbers in this assay, from the lowest: compounds 2, 4, 1 and 3 (each within the scatter of the next).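

In this assay, the first change read at the saturated chain carbon bound to an oxygen on an aromatic ring, methoxy to 2-(4-fluorophenyl)ethoxy, gives a number 4.7 percentage points lower from compound 3 to compound 4 (within the scatter) as its step. This position therefore takes 4-fluorobenzyl, with its 8 heavy atoms and aromatic ring, without a step beyond the scatter, though one change cannot define the position. No supporting data bear on this result.

From the compounds shown here alone, whether an amine or a carboxylic acid in place of the fluorine, or a longer chain, would move the read-out beyond the scatter remains open.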